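Nitrophenyl in place of chloromethylphenyl: lipophilicity estimate

The source may report more compounds than this note shows. Statements on the series, on what has been measured and on what is new or still open speak of the compounds shown alone.

Measured compounds:
compound 1, `Cc1cc(Oc2ccc(/C=N/NC(=S)Nc3ccc(F)cc3)cc2)ccc1Cl`: 6.07
compound 2, `S=C(N/N=C/c1ccc(Oc2ccc3ccccc3c2)cc1)Nc1ccc(Cl)cc1`: 6.96
compound 3, `Cc1cc(Oc2ccc(/C=N/NC(=S)Nc3ccc(Cl)cc3)cc2)ccc1Cl`: 6.59

In a physicochemical assay for lipophilicity, in phosphate buffer, measured as octanol-water partition, with a stated time of 24 h (on this read-out lower numbers stand for lower lipophilicity and higher numbers for higher lipophilicity), compound 1 gives 6.07, the lowest of the three numbers; compound 3 sits nearest, and compound 2 furthest above it. Compound 4, `O=[N+]([O-])c1ccc(Oc2ccc(/C=N/NC(=S)Nc3ccc(F)cc3)cc2)cc1`, is not yet measured. It differs from compound 1 in one place: 4-nitrophenyl in place of 4-chloro-3-methylphenyl on an oxygen on an aromatic ring.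

Within the data shown here, two measured steps bear on this change, though neither is the same change. The step of a number 0.52 log units higher from compound 1 to compound 3 (beyond the scatter) shows that swapping one halogen for another at the far end of the shared core moves this assay by a modest amount. The step of a number 0.37 log units lower from compound 2 to compound 3 (beyond the scatter) shows that exchanging the group on the aromatic oxygen, the place altered here, also moves this assay by a modest amount. Among the measured compounds shown here, no measured step shows a nitrophenyl group entering. A group carrying two hydrogen-bond acceptors replacing one with none is expected to lower the number beyond the scatter, by a number 1.27 log units lower from compound 1 to compound 4 (beyond the scatter). Compound 4 is therefore estimated at 4.8, within 4.2 to 5.4.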

Compound 4, partition coefficient: 4.89
Beside the measured number, compound 4's estimate is 0.09 log units below it, and the stated range covers the measured number.
By their numbers in this assay, from the lowest: compound 4; then compound 1; then compound 3; then compound 2.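

In this assay, among these compounds, the group on an oxygen on an aromatic ring proves able to carry a much larger shift than the earlier compounds showed: the step of a number 1.18 log units lower from compound 1 to compound 4 (beyond the scatter) is large, whereas the step of a number 0.37 log units lower from compound 2 to compound 3 (beyond the scatter) at this same place is modest. The change also removes a group with 0 hydrogen-bond acceptors and brings in one with 2, so this position responds strongly to at least this one exchange. Nothing here gives a measured reason for the size of the step.

As far as these compounds go, the exchange alters several features at once, so the share of the nitro group and the share of the lost chloro and methyl groups remain open. From the compounds shown here alone, an unsubstituted phenyl or a 4-aminophenyl group at this place would help separate them, and whether the step holds with chloro in place of fluoro on the shared core also remains open.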